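The source may hold more compounds than are shown below. What is called first, only, known or untested is meant among the compounds shown, and "the series" means these compounds.

Measured so far:
compound 1, `CN(Cc1ccc(C(=O)O)cc1)c1ccc(OCc2c(-c3c(Cl)cccc3Cl)noc2C2CC2)nc1C(F)(F)F`: 30 nM
compound 2, `CC(C)c1onc(-c2c(Cl)cccc2Cl)c1COc1cnc(N(C)Cc2ccc(C(=O)O)cc2)c(Cl)c1`: 107 nM

Both compounds were tested in a functional assay on HEK293 cells for agonist activity at Bile acid receptor (Homo sapiens); on this read-out higher numbers stand for an effect only at larger amounts of compound and lower numbers for an effect already at smaller amounts. Compound 2 carries the higher of the two numbers, and the gap to compound 1 lies beyond the usual scatter of this assay, so compound 2 is the one that needs the larger amount to show its effect. The two compounds differ in more than one place, so no single structural change can be tied to that gap.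

Compound 3, `CC(C)c1onc(-c2c(Cl)cccc2Cl)c1COc1cnc(N(C)Cc2cccc(C(=O)O)c2)c(Cl)c1`, is built from compound 2 by moving the acid group around its ring: 3-carboxyphenyl in place of 4-carboxyphenyl on a saturated chain carbon bound to a nitrogen on an aromatic ring. Within the data shown here, nothing measured so far shows what this kind of move does. A moderate step towards a larger number is expected for compound 3, which would be a 3.3-fold higher number from compound 2 to compound 3 (0.51 log units; beyond the scatter). Compound 3 is estimated at 350 nM, with a range from 100 nM to 1500 nM.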

Compound 3, half-maximal effective concentration: 100 nM
Beside the measured number, compound 3's estimate is 3.5-fold (0.54 log units) above it; measured number inside the range.
By their numbers in this assay, from the lowest: compound 1; then compounds 3 and 2 (each within the scatter of the next).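

Among these compounds, compound 2 and compound 3 are the first pair here that differ in one place, so they give the first direct reading of where the acid group sits on its ring. In this assay, 3-carboxyphenyl in place of 4-carboxyphenyl on a saturated chain carbon bound to a nitrogen on an aromatic ring gives a step within the scatter (a 1.1-fold lower number from compound 2 to compound 3 (0.03 log units; within the scatter)), so this read-out does not separate the two placements on this core. Nothing given here offers an explanation for that result.

Still open, going by these compounds, is whether the same move would read alike on the core of compound 1, which differs from compound 2 in more than one place. Also open, on these data alone, is whether a tetrazole or an amide could stand in for the carboxylic acid on this ring.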